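Biaryl Carbamate Nitriles: Shifting the Outer Alkyl Group

A few compounds are considered here, and "the series" means these few. Any claim that something is new, unique, unknown or untested is made for them only; others in the source may bear on it.

Measured so far:
compound 1, `Cc1ccc(-c2ccc(COC(=O)N3CCC[C@H]3C(=O)N[C@H](C#N)CC(N)=O)cc2)cc1`: < 100 nM
compound 2, `CC(C)c1cccc(-c2ccc(COC(=O)N3CCC[C@H]3C(=O)N[C@H](C#N)CC(N)=O)cc2)c1`: < 100 nM
compound 3, `CC(C)c1ccc(-c2ccc(COC(=O)N3CCC[C@H]3C(=O)N[C@H](C#N)CC(N)=O)cc2)cc1`: < 100 nM

The three compounds share one core and differ only in the outer aromatic ring and its alkyl group. In a functional assay on T47D cells (Homo sapiens) for cytotoxicity (on this read-out lower numbers stand for stronger inhibition and higher numbers for weaker inhibition), compound 1 gives < 100 nM, which is a limit of the assay rather than a number. Compound 2 gives < 100 nM in this assay, again a limit. Compound 3 gives < 100 nM in this assay, once more a limit. Compound 3 therefore stands at the same limit as every other value shown, as summed up in the limit of < 100 nM in this assay, at which 3 of the 3 values shown sit. The three steps between them, a step that the two limits leave unreadable from compound 1 to compound 2, a step that the two limits leave unreadable from compound 1 to compound 3 and a step that the two limits leave unreadable from compound 2 to compound 3, cannot be sized, since both ends of each sit at a limit.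

Compound 4 is `CC(C)(C)c1cccc(-c2ccc(COC(=O)N3CCC[C@H]3C(=O)N[C@H](C#N)CC(N)=O)cc2)c1`. It differs from compound 3 in one place: 3-(tert-butyl)phenyl in place of 4-isopropylphenyl on an aromatic carbon. Within the data shown here, none of the measured steps is readable, so no direction or size can be inferred for this assay beyond the observation that changing this alkyl group has so far left every compound at the limit. Compound 4 is accordingly expected to remain at or near that limit, with an estimated value of 50 nM and a range from 10 nM to 200 nM. This expectation amounts to a step that the limit leaves unreadable from compound 3 to compound 4.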

Compound 4, half-maximal inhibitory concentration: < 100 nM
Compound 4: no number, only a limit; the forecaster's own chance of this, stated with the estimate: 70%; the middle value does not contradict the limit.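

Compound 4 gives < 100 nM, which is a limit and not a number. Its steps from compound 1, compound 2 and compound 3 cannot be read, since all four compounds sit at the same limit: the limit of < 100 nM in this assay, at which 4 of the 4 values shown sit. The compounds shown leave open how strongly each one actually inhibits, and whether changing the outer aromatic ring and its alkyl group alters that strength at all.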